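The source may hold more compounds than are shown below. What is called first, only, known or untested is meant among the compounds shown, and "the series" means these compounds.

Measured so far: compound 1 `CCn1ncc2c(F)cc(-c3ccc(C(CC)(CC)c4nnc[nH]4)c(=O)[nH]3)cc21` with > 3 h; compound 2 `CC(C)C(Cc1nnc[nH]1)c1ccc(-c2ccc3cccc(F)c3c2)[nH]c1=O` with < 0.0667 h.

In an ADME assay on microsomes from liver (Mus musculus) for metabolic stability (on this read-out higher numbers stand for a longer-lived compound and lower numbers for a shorter-lived compound), compound 1 reaches only a limit of the assay, > 3 h. Compound 2 likewise returns only a limit, < 0.0667 h, and so stands at the short-lived end of the two values shown. Compound 3 `CC(C)C(Cc1nnn[nH]1)c1ccc(-c2ccc3cccc(F)c3c2)[nH]c1=O` differs from compound 2 in one place: 1H-tetrazol-5-yl in place of 4H-1,2,4-triazol-3-yl on a saturated chain carbon, two bonds along the chain from an aromatic carbon. Among the measured compounds shown here, no measured pair shows this change, so its effect on this read-out is unknown. Compound 3 is expected to stay near the short-lived end, with a step of an at least 1.1-fold higher number from compound 2 to compound 3 (0.07 log units; that floor lies within the scatter) no larger than the scatter. Compound 3 is therefore estimated at 0.08 h, between 0.03 h and 0.3 h.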

Compound 3, half-life: 0.853 h
Estimate against measurement, compound 3: 11-fold (1.03 log units) below; measured number above the stated range.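

On a saturated chain carbon, two bonds along the chain from an aromatic carbon, the choice of ring proves to matter in this assay: 1H-tetrazol-5-yl in place of 4H-1,2,4-triazol-3-yl gives an at least 12-fold higher number from compound 2 to compound 3 (1.10 log units; beyond the scatter). This single-place pair shows that exchanging one ring carbon for nitrogen, with the heavy-atom count unchanged, is enough to move the read-out beyond the scatter. The true size of the step stays unknown because compound 2 gives only a limit: the limit of < 0.0667 h in this assay, at which 1 of the 3 values shown sits.

On these data alone, whether a carboxylic acid in this place would match the tetrazole remains open. So does whether the same exchange would carry over to the core of compound 1.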